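One Methoxy Removed from a Lipoxygenase Inhibitor

The source may hold more compounds than are shown below. What is called first, only, known or untested is meant among the compounds shown, and "the series" means these compounds.

Compound 1 `COc1cccc(/C=C/C(=O)c2ccc(OCC=C(C)C)cc2O)c1OC`: a limit of the assay, > 100000 nM
Compound 2 `COc1ccc(/C=C/C(=O)c2ccc(OCC=C(C)C)cc2O)c(OC)c1OC`: a limit of the assay, > 100000 nM
Compound 3 `COc1ccc(/C=C/C(=O)c2ccc(OCC=C(C)C)cc2OCC=C(C)C)c(OC)c1OC`: 49000 nM

For the measured compounds named here, in an assay on isolated protein for inhibition of Polyunsaturated fatty acid 5-lipoxygenase (Homo sapiens) (on this read-out higher numbers stand for weaker inhibition and lower numbers for stronger inhibition), compound 3 gives the only number; compound 1 and compound 2 sit at the limit of > 100000 nM in this assay, at which 2 of the 3 values shown sit. The change 3-methylbut-2-en-1-yl in place of hydrogen on an oxygen on an aromatic ring brings an at least 2.0-fold lower number from compound 2 to compound 3 (0.30 log units; that floor lies within the scatter). The change hydrogen in place of methoxy on an aromatic carbon brings a step that the two limits leave unreadable from compound 2 to compound 1.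

Compound 4 `COc1ccc(/C=C/C(=O)c2ccc(OCC=C(C)C)cc2OCC=C(C)C)cc1OC` differs from compound 3 by hydrogen in place of methoxy on an aromatic carbon, the same kind of change as hydrogen in place of methoxy on an aromatic carbon, though the place differs: ortho to a large group in one, para to a large group in the other. The two cores differ by 3-methylbut-2-en-1-yl in place of hydrogen on an oxygen on an aromatic ring.

For compound 4 the step of a 1.2-fold higher number from compound 3 to compound 4 (0.09 log units; within the scatter) is expected, since a step that the two limits leave unreadable from compound 2 to compound 1 cannot be read. Compound 4 is thus estimated at 60000 nM, between 25000 nM and 150000 nM.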

Compound 4, half-maximal inhibitory concentration: 9000 nM
Beside the measured number, compound 4's estimate is 6.7-fold (0.82 log units) above it; the whole stated range lies above it.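

In this assay, hydrogen in place of methoxy brings a 5.4-fold lower number from compound 3 to compound 4 (0.74 log units; beyond the scatter), so on this core the change has a clear effect. This single step does not show that the effect carries over to another core, and the methoxy also leaves from a different place in the two pairs. The same kind of change from compound 2 to compound 1 cannot be read, because both values are limits of the assay rather than numbers: the limit of > 100000 nM in this assay, at which 2 of the 4 values shown sit.

From the compounds shown here alone, whether the step would hold with the methoxy leaving from the same place on both cores remains open. Also open, going by these compounds, is what an amine, a carboxylic acid or a longer chain in that place would do to inhibition on either core.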